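The compounds below may be only part of what the source reports. "The series", "measured", "known", "first", "only" and "open" are said of these compounds alone.

Measured compounds:
- compound 1, `CSc1cc(C)nc(SC)c1NC(=O)N(Cc1ccccc1)Cc1cccc(-c2cc[nH]n2)c1`: 0.046 mg/kg
- compound 2, `CSc1cc(C)nc(SC)c1NC(=O)N(Cc1ccc(-c2cnn(C)c2)cc1)C1CCCCCC1`: limit of > 0.1 mg/kg
- compound 3, `Cc1cc(C)c(NC(=O)N(Cc2cccc(-n3cccc3)c2)C2CCCCCC2)c(C)c1`: 0.17 mg/kg

Three compounds carry a value in a functional assay on a cell-free system (plasma) with sterol O-acyltransferase, Soat (Rattus norvegicus) as the target; a lower number here means that less compound is needed, a higher number that more compound is needed for the effect. Compound 1 gives 0.046 mg/kg. For compound 2 this assay reports only a limit, > 0.1 mg/kg, and not a number. Compound 3 gives 0.17 mg/kg, the highest of the two numbers shown; its nearest neighbour is compound 1, whose number is lower by a margin beyond the scatter. The limit of compound 2 sits where (the limit of > 0.1 mg/kg in this assay, at which 1 of the 3 values shown sits).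

Compound 4, `Cc1cc(C)c(NC(=O)N(Cc2cccc(-c3ccn(C)n3)c2)C2CCCCCC2)c(C)c1`, has not yet been measured. It differs from compound 3 in one place: 1-methyl-1H-pyrazol-3-yl in place of 1H-pyrrol-1-yl on an aromatic carbon. Among the measured compounds shown here, no measured pair shows this exact change, so the size of the step can only be guessed. Compound 1, which carries a pyrazolyl on a different core, gives the lower number 0.046 mg/kg. Compound 2 with a methylpyrazolyl reaches only a limit. The two do not point the same way.

Compound 4 is therefore expected to stay close to compound 3, with the step of a 1.1-fold lower number from compound 3 to compound 4 (0.05 log units; within the scatter) judged to lie within the scatter. The estimate for compound 4 in this assay is 0.15 mg/kg, with a range from 0.05 mg/kg to 0.45 mg/kg.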

Compound 4, dose for half-maximal effect: < 1 mg/kg
Compound 4 ended at the assay's limit (the forecaster's own chance of this, stated with the estimate: 20%); the middle value is on the limit's open side.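

For compound 4, this assay reports only a limit, < 1 mg/kg, and not a number, so the step from compound 3 to compound 4 cannot be read. The compounds shown leave open whether 1-methyl-1H-pyrazol-3-yl in place of 1H-pyrrol-1-yl on an aromatic carbon lowers or raises the number, and by how much.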